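The source may hold more compounds than are shown below. What is called first, only, known or untested is meant among the compounds shown, and "the series" means these compounds.

Compound 1 `CC1(c2ccc(-c3ccccc3C#N)cc2)CC(S(=O)(=O)c2ccc(F)cc2)=C(c2ccc(/C(N)=N\O)cc2)O1` gives 58300 nM in an ADME assay on HepG2 cells (Homo sapiens) for cytotoxicity, read by MTT assay, with a stated time of 72 h; a lower number here means that less compound is tolerated, a higher number that more compound is tolerated. Compound 2 `CC1(c2ccc(-c3cccc([N+](=O)[O-])c3)cc2)CC(S(=O)(=O)c2ccc(F)cc2)=C(c2ccc(/C(N)=N\O)cc2)O1` reaches only a limit of this assay, > 50000 nM. The step that the limit leaves unreadable from compound 1 to compound 2 cannot be sized because of the limit of > 50000 nM in this assay, at which 1 of the 2 values shown sits. Compound 3 `COc1cc(-c2ccc(C3(C)CC(S(=O)(=O)c4ccc(F)cc4)=C(c4ccc(/C(N)=N\O)cc4)O3)cc2)cc(OC)c1OC` carries 3,4,5-trimethoxyphenyl in place of 3-nitrophenyl on an aromatic carbon. Within the data shown here, no measured step bears on this change, and the single step known stops at the limit, so nothing here points in either direction beyond the scatter. Compound 3 is therefore expected to sit near that limit, estimated at 60000 nM with a range from 30000 nM to 120000 nM. The step that the limit leaves unreadable from compound 2 to compound 3 is expected to be small.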

Compound 3, half-maximal cytotoxic concentration: > 50000 nM
Compound 3 was reported as a limit; the forecaster's own chance of this, stated with the estimate: 60%; the middle value is on the limit's open side.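

No step can be read among compound 1, compound 2 and compound 3, because compound 2 and compound 3 stop at a limit: the limit of > 50000 nM in this assay, at which 2 of the 3 values shown sit. As far as these compounds go, whether 2-cyanophenyl, 3-nitrophenyl and 3,4,5-trimethoxyphenyl truly differ in this assay remains open.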